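Swapping 2-methoxyphenyl for 4-methoxyphenyl in compound 3

The compounds below may be only part of what the source reports. "The series", "measured", "known", "first", "only" and "open" are said of these compounds alone.

Measured so far in a functional assay on PC-3 cells (Homo sapiens) for inhibition, with a stated time of 48 h, tested at 50 uM; a lower number here means less inhibition of growth, a higher number more inhibition of growth at the concentration tested:
- compound 1 `C=C[C@@](C)(/C=C/c1ccc(OC(=O)CCCC)cc1)CCC=C(C)C`: 42%
- compound 2 `C=C[C@@](C)(/C=C/c1ccc(O)c(N)c1)CCC=C(C)C`: 28%
- compound 3 `COc1ccccc1/C=C/[C@@](C)(/C=C/c1ccc(O)cc1)CCC=C(C)C`: 46%

Compound 3 reaches 46% in this assay. Compound 1, at 42%, lies within the usual scatter of compound 3. Compound 2, at 28%, falls below compound 3 by more than the scatter.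

The next compound to be tested is compound 4 `COc1ccc(/C=C/[C@@](C)(/C=C/c2ccc(O)cc2)CCC=C(C)C)cc1`. It has the same atoms as compound 3, joined differently, with 4-methoxyphenyl in place of 2-methoxyphenyl on a double-bonded chain carbon bound to a double-bonded chain carbon.

Among the compounds with values here, no measured pair here differs in one place, so the data offer no direct guide to this change. No step beyond the scatter is expected in this assay, and neither direction is favoured. The estimate amounts to a number 1 percentage points lower from compound 3 to compound 4 (within the scatter), an expected change that stays within the scatter. Compound 4 is estimated at 45%, with an expected range from 32% to 58%.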

Compound 4, percent growth inhibition at one concentration: 50%
For compound 4 the middle estimate is 5 percentage points below the measured one; measured number inside the range.
By their numbers in this assay, from the lowest: compound 2; then compounds 1, 3 and 4 (each within the scatter of the next).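

In this assay, 4-methoxyphenyl in place of 2-methoxyphenyl on a double-bonded chain carbon bound to a double-bonded chain carbon gives a number 4 percentage points higher from compound 3 to compound 4 (within the scatter). This is the only pair shown that differs in one place, and it shows that, at this position, the two methoxyphenyl groups cannot be told apart by percent growth inhibition at the concentration tested. Nothing available explains this result.

The compounds shown leave open whether a different group at this position, such as an unsubstituted phenyl or a carboxylic acid on the phenyl ring, would give a step beyond the scatter. They also leave open whether 3-methoxyphenyl would stay within the scatter of these two groups.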